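Amide-side aryl variation on the hydroxy-oxo core: methoxy for methyl

The source may report more compounds than this note shows. Statements on the series, on what has been measured and on what is new or still open speak of the compounds shown alone.

Measured so far in a functional assay on the whole organism for inhibition, with Rattus norvegicus as the target, read by cytopathic effect and paw edema, at a dose of 100 mg/kg by the oral route; a higher number here means more inhibition at the dose given (going by the name of the read-out), a lower number less inhibition:
compound 1, `O=C(Nc1ccccn1)c1c(O)c2cccnc2n(-c2ccccc2)c1=O`, 14.6%
compound 2, `Cc1cccc(NC(=O)c2c(O)c3cccnc3n(-c3ccccc3)c2=O)c1`, 4.5%

Going by the values given here, compound 2 holds the lowest of the two numbers in this assay ; the one step measured, a number 10.1 percentage points lower from compound 1 to compound 2 (beyond the scatter), is modest and concerns a different change on the amide-type nitrogen. Compound 3, `COc1cccc(NC(=O)c2c(O)c3cccnc3n(-c3ccccc3)c2=O)c1`, differs from compound 2 by methoxy in place of methyl on an aromatic carbon. Among the compounds with values here, no measured step touches the methyl-to-methoxy exchange itself, so no shift beyond the scatter is expected: compound 3 is estimated at 7% (range 0% to 20%), an expected step of a number 2.5 percentage points higher from compound 2 to compound 3 (within the scatter).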

Compound 3, a percentage reported as inhibition, in the whole organism at one dose (the size of the read-out at that dose, not a potency): 20.7%
For compound 3 the middle estimate is 13.7 percentage points below the measured one, outside the stated range (above it).
By their numbers in this assay, from the lowest: compound 2; then compounds 1 and 3 (each within the scatter of the next).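

On the phenyl of the amide, the exchange of methyl for methoxy registers in this assay, a number 16.2 percentage points higher from compound 2 to compound 3 (beyond the scatter), so this aromatic carbon is not indifferent to the group it carries. With 3-methoxyphenyl on the amide nitrogen the result is not separable from pyridin-2-yl, a number 6.1 percentage points higher from compound 1 to compound 3 (within the scatter), so a phenyl at this nitrogen does not by itself go with the low number of compound 2. Nothing available bears on why methoxy and methyl read differently here. Still open, going by these compounds, is how a hydroxy, an ethyl or an amine on this same carbon would read.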